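From methoxy to bromo on compound 1

A few compounds are considered here, and "the series" means these few. Any claim that something is new, unique, unknown or untested is made for them only; others in the source may bear on it.

In an in vivo ADME assay on the whole organism (strain Sprague-Dawley) for pharmacokinetics, with Rattus norvegicus as the target (a higher number here means that a larger share of the oral dose reaches the circulation, a lower number that a smaller share of the oral dose reaches the circulation), compound 1 (`COc1cc(C(=O)N2[C@@H](c3nccs3)[C@@H](C(N)=O)C[C@@]2(CC(C)C)C(=O)O)ccc1C(C)(C)C`) gives 0.6% and stands lowest of the three measured compounds. Compound 2 (`COC[C@H]1C[C@@](CC(C)C)(C(=O)O)N(C(=O)c2ccc(C(C)(C)C)c(OC)c2)[C@H]1c1nccs1`) gives 59% while compound 3 (`COC[C@@H]1C[C@@](CC(C)C)(C(=O)O)N(C(=O)c2ccc(C(C)(C)C)c(OC)c2)[C@H]1c1nccs1`) gives 44% and these two differ only in configuration as drawn (the fact that compounds 2 and 3 differ only in the configuration as drawn). Putting methoxymethyl in place of carbamoyl on a saturated ring carbon gave the large a number 58.4 percentage points higher from compound 1 to compound 2 (beyond the scatter) and changing one stereocentre gave the modest a number 15 percentage points lower from compound 2 to compound 3 (beyond the scatter) as a second step.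

Compound 4 (`CC(C)C[C@@]1(C(=O)O)C[C@H](C(N)=O)[C@H](c2nccs2)N1C(=O)c1ccc(C(C)(C)C)c(Br)c1`) keeps the carbamoyl and changes elsewhere: bromo in place of methoxy on an aromatic carbon with bromo in place of methoxy on an aromatic carbon, ortho to a tert-butyl group. Neither measured step touches that aromatic carbon, so neither gives a size for this change. The carbamoyl stays, as in compound 1 at 0.6% so the number is expected to remain low. No step beyond the scatter is expected, the estimated change being a number 2.4 percentage points higher from compound 1 to compound 4 (within the scatter) at most modestly upward. For compound 4 the expected value is 3% within an estimated range of 0.5% to 15% in this measure.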

Compound 4, oral bioavailability: 2%
Estimate against measurement, compound 4: 1 percentage points above; the measured number falls inside the stated range.
By their numbers in this assay, from the lowest: compounds 1 and 4 (each within the scatter of the next); then compound 3; then compound 2.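

Within the data shown here, on this aromatic carbon, ortho to a tert-butyl group, the earlier compounds offered no comparison, and the first step to touch it shows that bromo in place of methoxy does not move the number in this assay beyond the scatter (a number 1.4 percentage points higher from compound 1 to compound 4 (within the scatter)). With the carbamoyl kept, this swap leaves the share of the oral dose reaching the circulation as low as in compound 1, whereas the change on the saturated ring carbon gave a large step (a number 58.4 percentage points higher from compound 1 to compound 2 (beyond the scatter)). Nothing among the data given explains why this swap has so little effect.

From the compounds shown here alone, whether bromo would behave the same once methoxymethyl replaces the carbamoyl remains open. So does the effect of a different group on this aromatic carbon, such as a nitrile or an amine.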